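A few compounds are considered here, and "the series" means these few. Any claim that something is new, unique, unknown or untested is made for them only; others in the source may bear on it.

Measured so far in an ADME assay on the whole organism (Rattus norvegicus, strain Sprague-Dawley) for pharmacokinetics, read by LC-MS, with a stated time of 30 min; on this read-out lower numbers stand for narrower distribution and higher numbers for wider distribution into tissues:
compound 1 `N#Cc1ccc(O[C@H]2CN(S(=O)(=O)c3ccc(Cl)cc3Cl)C[C@@]2(O)CO)cc1F`: 3.2 L/kg
compound 2 `N#Cc1ccc(O[C@H]2CN(S(=O)(=O)c3ccc(C(F)(F)F)cc3)C[C@@]2(O)CO)cc1F`: 5.9 L/kg
compound 3 `N#Cc1ccc(O[C@H]2CN(S(=O)(=O)c3ccccc3C#N)C[C@@]2(O)CO)cc1F`: 0.9 L/kg

Of these three, compound 3 has the lowest number, at 0.9 L/kg, and its gaps to the other two lie beyond the scatter. Compound 4 `N#Cc1ccc(O[C@H]2CN(S(=O)(=O)c3ccc(Cl)cn3)C[C@@]2(O)CO)cc1F` keeps the shared core and differs from compound 3 only on a sulfonyl sulfur, where 5-chloropyridin-2-yl stands in place of 2-cyanophenyl (5-chloropyridin-2-yl in place of 2-cyanophenyl on a sulfonyl sulfur).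

Among the measured compounds shown here, no measured step makes this exact change, so the evidence is indirect. Only compound 3 carries 2-cyanophenyl, and both steps that bring it in go down: a 3.6-fold lower number from compound 1 to compound 3 (0.55 log units; beyond the scatter), and a 6.6-fold lower number from compound 2 to compound 3 (0.82 log units; beyond the scatter). The two other groups stay close to each other, with a 1.8-fold higher number from compound 1 to compound 2 (0.27 log units; within the scatter). Compound 1, at 3.2 L/kg, is the nearest comparison, since its 2,4-dichlorophenyl group also holds chlorine. For the measured compounds named here, no measured compound has an aromatic ring with a hetero atom, so that part of the change remains untested.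

Leaving 2-cyanophenyl is therefore expected to raise the number, though probably not all the way to that of compound 1. In this assay the expected step is a 2.2-fold higher number from compound 3 to compound 4 (0.35 log units; beyond the scatter). For compound 4 the estimate is 2 L/kg, with an expected range of 0.9 L/kg to 4.5 L/kg.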

Compound 4, volume of distribution at steady state: 2.2 L/kg
The estimate for compound 4 lay 1.1-fold (0.04 log units) below the measured number; low and high end bracket the measured number.
By their numbers in this assay, from the lowest: compound 3; then compounds 4, 1 and 2 (each within the scatter of the next, the first and the last beyond it).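

In this assay, among the compounds shown here, 5-chloropyridin-2-yl is the first group on the sulfonyl sulfur whose aromatic ring holds a hetero atom, and it separates clearly from both 2-cyanophenyl, with a 2.4-fold higher number from compound 3 to compound 4 (0.39 log units; beyond the scatter), and 4-(trifluoromethyl)phenyl, with a 2.7-fold lower number from compound 2 to compound 4 (0.43 log units; beyond the scatter). Against 2,4-dichlorophenyl, the step is a 1.5-fold lower number from compound 1 to compound 4 (0.16 log units; within the scatter), which lies within the scatter, so these two groups cannot be told apart here, and the low number of compound 3 remains specific to 2-cyanophenyl among the four groups shown. Nothing given here explains why these groups differ in this way.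

Compound 4 differs from compound 3 in both its ring and its substituent, so the shares of the ring nitrogen, the chlorine and the loss of the nitrile cannot be separated. A plain pyridin-2-yl group or a cyano-substituted pyridin-2-yl group on the same sulfonyl sulfur would be the closest comparisons, and the compounds shown leave open how either would compare with compound 3 and compound 4.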